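This account rests on a few compounds, and the source may have more. Where it says the series, first, only, none or still open, it means among the compounds named here.

In an ADME assay on the whole organism for pharmacokinetics, with Rattus norvegicus as the target, with a stated time of 6 h, at a dose of 10 mg/kg by the oral route (a higher number here means more compound in the circulation at the dose given, a lower number less compound in the circulation), compound 1 `CC[C@H]1CN(c2nc(N)c(C(=O)NCCO)nc2Cl)CCN1C1CCN(C(=O)c2ccc(Cl)nc2N)CC1` gives 3340 ng.h/mL, compound 2 `CC[C@H]1CN(c2ncc(C(N)=O)nc2C(F)(F)F)CCN1C1CCN(C(=O)c2ccc(Cl)nc2N)CC1` gives 8280 ng.h/mL and compound 3 `CC[C@H]1CN(c2ncc(C(=O)NC)nc2C(F)(F)F)CCN1C1CCN(C(=O)c2ccc(Cl)nc2N)CC1` gives 3550 ng.h/mL. Compound 3 therefore stands beyond the scatter under compound 2, while its number and that of compound 1 lie within the scatter of each other.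

Compound 4 `CC[C@H]1CN(c2ncc(C(=O)NC3CC3)nc2C(F)(F)F)CCN1C1CCN(C(=O)c2ccc(Cl)nc2N)CC1` carries cyclopropyl in place of methyl on an amide-type nitrogen. Going by the values given here, one measured step bears directly on this place. With methyl in place of hydrogen on an amide-type nitrogen, the number moved a 2.3-fold lower number from compound 2 to compound 3 (0.37 log units; beyond the scatter), a modest change. Compound 1 also has a substituent on an amide-type nitrogen, but it differs from compound 3 in other places too, so it offers no clean comparison. Among the compounds with values here, no measured compound carries cyclopropyl on that nitrogen, and a single step is thin ground for a forecast.

Taking that one step as a weak guide to direction, a further small fall in this assay is expected, most likely within the scatter. The expected change is a 1.4-fold lower number from compound 3 to compound 4 (0.14 log units; within the scatter). The estimated value for compound 4 is 2600 ng.h/mL, with an expected range from 1100 ng.h/mL to 6000 ng.h/mL.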

Compound 4, area under the concentration-time curve: 2090 ng.h/mL
Estimate against measurement, compound 4: 1.2-fold (0.09 log units) above, within the range that was stated.
By their numbers in this assay, from the lowest: compounds 4, 1 and 3 (each within the scatter of the next); then compound 2.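

At this amide-type nitrogen, cyclopropyl in place of methyl gives a 1.7-fold lower number from compound 3 to compound 4 (0.23 log units; within the scatter) in this assay and so leaves the two compounds within the scatter of each other, even though cyclopropyl brings a three-membered non-aromatic ring of carbon only where methyl has none. Cyclopropyl in place of the amide hydrogen gives a 4.0-fold lower number from compound 2 to compound 4 (0.60 log units; beyond the scatter) and is a step beyond the scatter, as is a 2.3-fold lower number from compound 2 to compound 3 (0.37 log units; beyond the scatter) for methyl in that place. Among these three compounds, then, the clear separation lies between the amide hydrogen and either carbon group, and not between methyl and cyclopropyl, while nothing shown here gives a reason for these numbers.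

The compounds shown leave open whether a longer chain such as n-butyl, a bulkier ring such as cyclohexyl, or a chain ending in an amine on this nitrogen would stay close to compound 3 and compound 4 or move further away. They also leave open whether the same steps would hold on a core without trifluoromethyl, since compound 1 differs in other places too and offers no clean comparison.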